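A few compounds are considered here, and "the series" means these few. Any claim that something is new, unique, unknown or untested is made for them only; others in the source may bear on it.

Compound 1, `Oc1ccc(-c2cc(-c3ccc(F)cc3)cc(-c3cccc(O)c3)n2)cc1`, carries two hydroxyphenyl groups and a 4-fluorophenyl group on its core. In a functional assay on HeLa cells (Homo sapiens) for inhibition (a higher number here means a weaker inhibitor, a lower number a stronger inhibitor), compound 1 gives 8080 nM. Compound 2, `Oc1ccc(-c2cc(-c3ccc(F)cc3)cc(-c3ccc(O)cc3)n2)cc1`, differs from it by 4-hydroxyphenyl in place of 3-hydroxyphenyl on an aromatic carbon. In this assay compound 2 gives 8680 nM, so that the step of a 1.1-fold higher number from compound 1 to compound 2 (0.03 log units; within the scatter) leaves the two compounds indistinguishable in this assay.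

Compound 3, `Oc1cccc(-c2cc(-c3ccccc3OC(F)(F)F)cc(-c3ccccc3O)n2)c1`, rests on a core whose difference from that of compound 1 is not broken down here. In this assay compound 3 gives 15200 nM, a value that lies within the scatter of both compound 1 and compound 2, so no ranking among the three is warranted.

Compound 4, `Oc1ccc(-c2cc(-c3ccccc3OC(F)(F)F)cc(-c3ccccc3O)n2)cc1`, has not yet been measured. It is related to compound 3 by 4-hydroxyphenyl in place of 3-hydroxyphenyl on an aromatic carbon. This is the same kind of change as that from compound 1 to compound 2, though the surroundings differ: in compound 1 the site is meta to a 4-fluorophenyl group and meta to a 4-hydroxyphenyl group, whereas in compound 3 it is meta to a 2-hydroxyphenyl group and meta to a large group. For the measured compounds named here, because the only measured example of this change, a 1.1-fold higher number from compound 1 to compound 2 (0.03 log units; within the scatter), stayed within the scatter, a similarly small step is expected, a 1.1-fold higher number from compound 3 to compound 4 (0.02 log units; within the scatter). Compound 4 is accordingly estimated at 16000 nM in this assay, with a plausible range from 8000 nM to 32000 nM.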

Compound 4, half-maximal inhibitory concentration: 6010 nM
Estimate against measurement, compound 4: 2.7-fold (0.43 log units) above; the whole stated range lies above it.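

In this assay, 4-hydroxyphenyl in place of 3-hydroxyphenyl gives a 2.5-fold lower number from compound 3 to compound 4 (0.40 log units; beyond the scatter), so on this core the change leaves a readable mark on the number, in the direction of a stronger inhibitor. The change therefore does not carry over at a constant size from one core to the other, and the step on one core would have been a poor guide to the step on the other: the same change on two cores in this assay, a 1.1-fold higher number (0.03 log units; within the scatter) from compound 1 to compound 2 and a 2.5-fold lower number (0.40 log units; beyond the scatter) from compound 3 to compound 4, 2.7-fold (0.43 log units) apart, beyond the scatter of two such steps This does not show which feature of the cores sets the two steps apart, since the two pairs differ from each other in more than one place, and two pairs give no rule for what the change would do on a third core.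

The compounds shown leave open whether the step depends on the 4-fluorophenyl group, the trifluoromethoxy-bearing phenyl group or the 2-hydroxyphenyl group, as no pair here separates these groups from one another. They also leave open how an amine or a carboxylic acid in place of the hydroxyl group on the exchanged phenyl ring would read in this assay.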